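The source may report more compounds than this note shows. Statements on the series, on what has been measured and on what is new or still open speak of the compounds shown alone.

Measured compounds:
Compound 1, `OC(CCn1nc2c(Br)c(Br)c(Br)c(Br)c2n1)c1cccc(Br)c1`: 52%
Compound 2, `OC(CCn1nc2c(Br)c(Br)c(Br)c(Br)c2n1)c1ccccc1`: 99%

Both compounds were tested in a functional assay on MCF7 cells (Homo sapiens) for antiproliferative activity, read by MTT assay, with a stated time of 24 h, tested at 25 uM; a lower number here means a stronger effect, a higher number a weaker effect of the compound at the concentration tested. Compound 2, which carries a plain phenyl ring on the shared core, gives the higher of the two numbers; in this assay compound 2 gives 99%, whereas compound 1 gives 52%, so compound 2 shows the weaker effect of the pair.

Compound 3 is `OC(CCn1nc2c(Br)c(Br)c(Br)c(Br)c2n1)c1ccc(Br)cc1`, not yet measured. It differs from compound 2 in one place: bromo in place of hydrogen on an aromatic carbon. Within the data shown here, the bromo of compound 1 sits on another carbon of that same ring, so the one measured step is only a loose guide. That step, a number 47 percentage points higher from compound 1 to compound 2 (beyond the scatter), shows that taking a bromo off the phenyl ring went with a large rise in the number, beyond the scatter. Putting a bromo back onto the ring in compound 3 is therefore expected to lower the number again, and the step is estimated as a number 37 percentage points lower from compound 2 to compound 3 (beyond the scatter). For compound 3 in this assay a value of about 62% is expected, with a likely range from 35% to 95%.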

Compound 3, a percentage reported as activity, at one concentration (the size of the read-out at that concentration, not a potency): 59%
For compound 3 the middle estimate is 3 percentage points above the measured one; measured number inside the range.
By their numbers in this assay, from the lowest: compounds 1 and 3 (each within the scatter of the next); then compound 2.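

In this assay, the change from phenyl to 4-bromophenyl, a number 40 percentage points lower from compound 2 to compound 3 (beyond the scatter), shows that a bromo on this ring carbon, para to a large group, goes with a much stronger effect at the concentration tested. Putting 4-bromophenyl in place of 3-bromophenyl gives a number 7 percentage points higher from compound 1 to compound 3 (within the scatter), so across these compounds the presence of a bromo on the phenyl ring separates the numbers, while the two ring places that carry it cannot be told apart in this assay. Nothing measured alongside these numbers bears on the reason for this link between the bromo and the effect.

The compounds shown leave open whether the drop belongs to bromo itself or would also appear with another group on that ring carbon, such as a chloro, a methoxy or an amine. They also leave open how the number would respond to changes away from the phenyl ring, such as a longer chain or a carboxylic acid in place of the hydroxyl.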